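A few compounds are considered here, and "the series" means these few. Any claim that something is new, unique, unknown or untested is made for them only; others in the source may bear on it.

Measured in a functional assay on OVCAR-8 cells (Homo sapiens) for inhibition, read by sulforhodamine B assay, with a stated time of 48 h, tested at 0.1 uM; a higher number here means a weaker effect of the compound at the concentration tested, a lower number a stronger effect:
compound 1 `COc1cc(Cl)cc(-c2nn(-c3cccc(NC(=O)Nc4ccc(Cl)c(C(F)(F)F)c4)c3)cc2-c2ccncc2)c1`: 96%
compound 2 `COc1cc(Cl)cc(-c2nn(-c3cccc(NC(=O)Nc4cc(C(F)(F)F)cc(C(F)(F)F)c4)c3)cc2-c2ccncc2)c1`: 105%
compound 3 `COc1cc(Cl)cc(-c2nn(-c3cccc(NC(=O)Nc4ccc(Cl)c(Cl)c4)c3)cc2-c2ccncc2)c1`: 101%

All three numbers are close to the level at which the cells grow unaffected, so none of the compounds has a clear effect at this concentration. Compound 3 lies within the usual scatter of compound 1 and of compound 2 alike. Compound 4 `COc1cc(Cl)cc(-c2nn(-c3cccc(NC(=O)Nc4cccc(C(F)(F)F)c4)c3)cc2-c2ccncc2)c1` differs from compound 3 by 3-(trifluoromethyl)phenyl in place of 3,4-dichlorophenyl on an amide-type nitrogen. Among the compounds with values here, the one measured step that bears on this exchange is a number 5 percentage points higher from compound 1 to compound 3 (within the scatter), an exchange of the same two groups on the same ring. Within the data shown here, no measured step covers the loss of the second chloro. On this basis the step expected is a number 1 percentage points lower from compound 3 to compound 4 (within the scatter), nothing beyond the scatter. Compound 4 is therefore estimated at 100%, with a likely range from 88% to 112%.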

Compound 4, a percentage reported as activity, at one concentration (the size of the read-out at that concentration, not a potency): 99%
The estimate for compound 4 lay 1 percentage points above the measured number; measured number inside the range.
By their numbers in this assay, from the lowest: compounds 1, 4, 3 and 2 (each within the scatter of the next).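

In this assay the phenyl group on the amide-type nitrogen can carry a single trifluoromethyl without any visible shift: the comparisons give a number 2 percentage points lower from compound 3 to compound 4 (within the scatter) for the exchange of 3,4-dichlorophenyl, a number 6 percentage points lower from compound 2 to compound 4 (within the scatter) for the loss of a trifluoromethyl, and a number 3 percentage points higher from compound 1 to compound 4 (within the scatter) for the loss of a chloro. Across these four compounds, a second group on this ring, whether chloro or trifluoromethyl, therefore makes no difference that stands out from the scatter at this concentration. No evidence at hand explains this flat picture. As far as these compounds go, whether an amine or a carboxylic acid on this ring would move the number remains open.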